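The compounds below may be only part of what the source reports. "The series", "measured", "known", "first", "only" and "open" are said of these compounds alone.

Of the compounds shown here, three built on one shared core have been measured in a functional assay on HeLa cells (Homo sapiens) for antiproliferative activity, with a stated time of 24 h; a lower number here means a stronger inhibitor, a higher number a weaker inhibitor. Compound 1 `NC(=O)c1c(NC(=O)c2ccccc2)sc2c1CCN(C(=S)Nc1ccccc1Cl)C2` carries hydrogen on the aromatic carbon in question, and in this assay compound 1 gives > 50000 nM, which is a limit of the measurement rather than a number. Compound 2 `NC(=O)c1c(NC(=O)c2ccccc2F)sc2c1CCN(C(=S)Nc1ccccc1Cl)C2` carries fluoro in place of that hydrogen, and in this assay compound 2 gives 19400 nM. The step here is an at least 2.5-fold lower number from compound 1 to compound 2 (0.41 log units; beyond the scatter). Compound 3 `NC(=O)c1c(NC(=O)c2ccccc2I)sc2c1CCN(C(=S)Nc1ccccc1Cl)C2` carries iodo instead, and in this assay compound 3 gives only a limit, > 50000 nM. From the fluoro compound to the iodo compound the step is an at least 2.5-fold higher number from compound 2 to compound 3 (0.41 log units; beyond the scatter), while a step that the two limits leave unreadable from compound 1 to compound 3 because the limit of > 50000 nM in this assay, at which 2 of the 3 values shown sit, leaves no number on either side.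

Compound 4 `COc1ccccc1C(=O)Nc1sc2c(c1C(N)=O)CCN(C(=S)Nc1ccccc1Cl)C2` has not yet been measured. Compared with compound 3, the change is methoxy in place of iodo on an aromatic carbon. Within the data shown here, no measured step exchanges iodo for methoxy, so the expectation is loose: compound 2 with fluoro was the only one to give a number, compound 3 with iodo sits at the limit, and methoxy is neither. The expected step of an at least 1.2-fold lower number from compound 3 to compound 4 (0.09 log units; that floor lies within the scatter) is therefore modest at best and may be nothing beyond the scatter. Compound 4 is estimated at 40000 nM, with a range from 15000 nM to 100000 nM, and with a real chance that this assay again reports only a limit.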

Compound 4, half-maximal inhibitory concentration: > 50000 nM
Compound 4: a limit, no number (the forecaster's own chance of this, stated with the estimate: 50%); at least 1.2-fold (0.09 log units) between middle value and limit.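

With compound 4, methoxy joins hydrogen and iodo at the limit of this assay, so among compounds 1 to 4 only compound 2, with fluoro, gives a number at this position on the aromatic ring. Exchanging fluoro for methoxy produces an at least 2.5-fold higher number from compound 2 to compound 4 (0.41 log units; beyond the scatter), the same kind of loss already seen with iodo, so a second, quite different group has now failed to keep the measurable effect of fluoro. The steps to compound 4 from compound 1 and from compound 3 cannot be read, and methoxy therefore cannot be ranked against hydrogen or iodo, because neither side of either step gives a number: the limit of > 50000 nM in this assay, at which 3 of the 4 values shown sit.

The compounds shown leave open whether fluoro is alone in giving a number at this position, or whether chloro, methyl, hydroxyl or an amine in the same place would also do so. They also leave open whether fluoro at another position on this ring, or a second fluoro added to it, would give a lower number than compound 2 does.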